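This account rests on a few compounds, and the source may have more. Where it says the series, first, only, none or still open, it means among the compounds named here.

Measured so far in a functional assay on HT cells (Homo sapiens) for antiproliferative activity, read by fluorescence, with a stated time of 72 h; a lower number here means a stronger inhibitor of growth, a higher number a weaker inhibitor of growth:
compound 1, `CC(C)c1n[nH]c2c(NCc3ccc(-c4ccccn4)cc3)nc(SC(C)C(C)O)nc12`: 190 nM
compound 2, `CC(C)c1n[nH]c2c(NCc3ccc(-c4ccccn4)cc3)nc(SCCCN(C)C)nc12`: 105 nM
compound 3, `CC(C)c1n[nH]c2c(NCc3ccc(-c4ccccn4)cc3)nc(SC(CO)C(C)C)nc12`: 980 nM

Compound 3 stands at the highest number of the three. The two steps leading to it are both beyond the scatter: a 5.2-fold higher number from compound 1 to compound 3 (0.71 log units; beyond the scatter) and a 9.3-fold higher number from compound 2 to compound 3 (0.97 log units; beyond the scatter). Between compounds 1 and 2 the step of a 1.8-fold lower number from compound 1 to compound 2 (0.26 log units; within the scatter) is within the scatter, so the only clear movement in this set is the rise to compound 3, which carries 1-(hydroxymethyl)-2-methylpropyl on the sulfur.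

Compound 4, `CC(C)c1n[nH]c2c(NCc3ccc(-c4ccccn4)cc3)nc(SCCNC(N)=O)nc12`, is the next point. The change is 2-ureidoethyl in place of 1-(hydroxymethyl)-2-methylpropyl on a sulfur. Within the data shown here, no measured pair contains a ureido group, so the step can only be read against the two steps into compound 3. Both steps removed a branched group from the sulfur and both ran upward; going the other way, to a chain such as 2-ureidoethyl, the expectation is a downward step in this assay , most likely of a size between a 5.2-fold higher number from compound 1 to compound 3 (0.71 log units; beyond the scatter) and a 9.3-fold higher number from compound 2 to compound 3 (0.97 log units; beyond the scatter) rather than larger. The estimate for compound 4 is therefore 220 nM, within 70 nM to 700 nM, which corresponds to an expected step of a 4.5-fold lower number from compound 3 to compound 4 (0.65 log units; beyond the scatter).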

Compound 4, concentration for 50% growth inhibition: 240 nM
Estimate against measurement, compound 4: 1.1-fold (0.04 log units) below, and the stated range covers the measured number.
By their numbers in this assay, from the lowest: compounds 2, 1 and 4 (each within the scatter of the next, the first and the last beyond it); then compound 3.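

In this assay the sulfur position takes 2-ureidoethyl in place of 1-(hydroxymethyl)-2-methylpropyl with a clear drop in the number (a 4.1-fold lower number from compound 3 to compound 4 (0.61 log units; beyond the scatter)), although both groups count 6 heavy atoms, so heavy-atom count alone does not set the value here. The ureido end does not match the (dimethylamino)methyl end of the otherwise same chain (a 2.3-fold higher number from compound 2 to compound 4 (0.36 log units; beyond the scatter)), which gives the first separation beyond the scatter among the groups that sit at the lower end of the series. Against 2-hydroxy-1-methylpropyl no separation shows (a 1.3-fold higher number from compound 1 to compound 4 (0.10 log units; within the scatter)), so branching on the sulfur does not sort the series by itself: compound 1 is branched and still stays within the scatter of the unbranched compound 4, and the high number remains confined to compound 3.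

Still open, as far as these compounds go, is how a primary amine, a carboxylic acid, an acetamide or a longer chain ending in ureido would read at this position. No data on hand give a reason for any of these differences.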